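Methyl branching on the acid-bearing chain, two cores

A few compounds are considered here, and "the series" means these few. Any claim that something is new, unique, unknown or untested is made for them only; others in the source may bear on it.

Measured in a functional assay on CHO cells for antagonist activity at sphingosine 1-phosphate receptor 2 (Homo sapiens), read by calcium flux; on this read-out higher numbers stand for weaker inhibition and lower numbers for stronger inhibition:
compound 1 `C[C@@H](C(=O)O)c1nn(Cc2cn3cc(OCC4CC4)c(Cl)cc3n2)c2ccccc2c1=O`, 24 nM
compound 2 `O=C(O)Cn1nc(Cn2cc3cc(OCC4CC4)c(Cl)cc3n2)c2ccccc2c1=O`, 11 nM
compound 3 `O=C(O)Cc1nn(Cc2cn3cc(OCC4CC4)c(Cl)cc3n2)c2ccccc2c1=O`, 20 nM

Compounds 1 and 3 share one core; compound 2 carries the other, and the difference between the two cores is not broken down here. Compound 2 stands lowest of the three numbers, though its gap to compound 3 lies within the scatter, so no order between those two is claimed. Against compound 1 the gap is beyond the scatter.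

The branching change is seen once, (methyl in place of hydrogen on a saturated chain carbon bound to an aromatic carbon and a carbonyl carbon), giving a 1.2-fold higher number from compound 3 to compound 1 (0.08 log units; within the scatter).

Compound 4 `C[C@H](C(=O)O)n1nc(Cn2cc3cc(OCC4CC4)c(Cl)cc3n2)c2ccccc2c1=O` is not yet measured. It differs from compound 2 by methyl in place of hydrogen on a saturated chain carbon bound to an aromatic nitrogen and a carbonyl carbon. This is the same kind of change, not the same one: the chain carbon in compound 1 is bound to an aromatic carbon, in compound 4 to an aromatic nitrogen.

Resting on compound 3 to compound 1 giving a 1.2-fold higher number from compound 3 to compound 1 (0.08 log units; within the scatter), compound 4 is expected to stay near compound 2, with an estimated step of a 1.3-fold higher number from compound 2 to compound 4 (0.10 log units; within the scatter). Compound 4 is estimated at 14 nM, between 5 nM and 40 nM.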

Compound 4, half-maximal inhibitory concentration in the sphingosine 1-phosphate receptor 2 assay: 3.2 nM
Compound 4: middle estimate off by 4.4-fold (0.64 log units), on the high side; measured number outside the range, below it.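

In the sphingosine 1-phosphate receptor 2 assay, methyl in place of hydrogen on a saturated chain carbon bound to an aromatic nitrogen and a carbonyl carbon gives a 3.4-fold lower number from compound 2 to compound 4 (0.54 log units; beyond the scatter), so in this series the size of the step does not carry unchanged from one core to the other: the same change on two cores in the sphingosine 1-phosphate receptor 2 assay, a 1.2-fold higher number (0.08 log units; within the scatter) from compound 3 to compound 1 and a 3.4-fold lower number (0.54 log units; beyond the scatter) from compound 2 to compound 4, 4.1-fold (0.62 log units) apart, beyond the scatter of two such steps

In the sphingosine 1-phosphate receptor 2 assay compound 2 gives 11 nM and compound 4 gives 3.2 nM.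

This rests on a single pair per core, and the chain carbon is bound to an aromatic carbon in one pair and to an aromatic nitrogen in the other, so the gap cannot be assigned to the core as a whole or to that attachment alone. In a physicochemical assay for lipophilicity, at pH 7.4 (a higher number here means a more lipophilic compound, a lower number a more polar compound), compound 2 gives 2.79 and compound 4 gives 2.99. In the physicochemical assay the step reads a number 0.20 log units higher from compound 2 to compound 4 (within the scatter), and that read-out does not separate the pair.

Open, on these data alone, is whether ethyl or a second methyl on that chain carbon, or the opposite configuration of the 1-carboxyethyl group, would behave as methyl does on the core of compound 2. Also open, as far as these compounds go, is whether the step survives with an amide in place of the carboxylic acid.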